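This account rests on a few compounds, and the source may have more. Where it says the series, first, only, none or still open, it means among the compounds named here.

Measured so far:
- compound 1 `Cc1cccc(Cc2cc(Nc3nc(C)cn4c(-c5cn[nH]c5)cnc34)sn2)n1`: 3100 ng.h/mL
- compound 2 `Cc1cn2c(-c3cn[nH]c3)cnc2c(Nc2cc(C(c3ccccn3)N3CCCC3)ns2)n1`: 9.15 ng.h/mL

In an ADME assay on the whole organism for pharmacokinetics, with Rattus norvegicus as the target, with a stated time of 6 h, at a dose of 10 mg/kg by the oral route (a higher number here means more compound in the circulation at the dose given, a lower number less compound in the circulation), compound 1 gives 3100 ng.h/mL. In this assay compound 2 gives 9.15 ng.h/mL, the lower of the two numbers; the gap between compound 2 and compound 1 is far beyond the scatter, so compound 2 sits clearly at the bottom of what is known here.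

Compound 3 `Cc1cn2c(-c3cn[nH]c3)cnc2c(Nc2cc(C(NC3CCCC3)c3ccccn3)ns2)n1` is not yet measured. It differs from compound 2 in one place: cyclopentylamino in place of pyrrolidin-1-yl on a saturated chain carbon bound to two aromatic carbons. For the measured compounds named here, no measured pair shows this kind of change, so there is no measured step to lean on. The expectation is therefore a step from compound 2 to compound 3 of a 1.6-fold higher number from compound 2 to compound 3 (0.21 log units; within the scatter), that is, nothing beyond the scatter, with wide uncertainty either way. Compound 3 is estimated at 15 ng.h/mL, within a range from 3 ng.h/mL to 80 ng.h/mL.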

Compound 3, area under the concentration-time curve: 316 ng.h/mL
Compound 3: the middle estimate sits 21-fold (1.32 log units) below what was measured, and the stated range ends below it.
By their numbers in this assay, from the lowest: compound 2; then compound 3; then compound 1.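

On the saturated chain carbon bound to two aromatic carbons, cyclopentylamino in place of pyrrolidin-1-yl gives a 35-fold higher number from compound 2 to compound 3 (1.54 log units; beyond the scatter) in this assay. This position is therefore far from indifferent to which five-membered ring it carries, even though the change is small on paper: pyrrolidin-1-yl has 5 heavy atoms and 0 hydrogen-bond donors, while cyclopentylamino has 6 heavy atoms and 1 hydrogen-bond donor. Nothing available explains the step.

This single pair cannot separate the effect of the amine hydrogen from that of the all-carbon ring or of the ring's placement on the nitrogen. Cyclobutylamino, cyclohexylamino or an open-chain isopropylamino at the same carbon would show whether the step depends on the ring itself, and a cyclopentyl(methyl)amino group would show whether it depends on the amine hydrogen.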